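This account rests on a few compounds, and the source may have more. Where it says the series, first, only, none or still open, it means among the compounds named here.

In a functional assay on NCI-H520 cells (Homo sapiens) (on this read-out lower numbers stand for stronger inhibition of growth and higher numbers for weaker inhibition of growth), three compounds that share one core have been measured. Compound 1 `O=S(=O)(/C=C/c1ccc(Cl)c(Cl)c1)Cc1ccc(Nc2ncnc3ccc(Br)cc23)cc1` reads > 100000 nM, which is a limit of the assay and not a number. Compound 2 `O=S(=O)(/C=C/c1ccc(Br)cc1)Cc1ccc(Nc2ncnc3ccc(Br)cc23)cc1` gives 20000 nM. Compound 3 `O=S(=O)(/C=C/c1ccc(Cl)cc1)Cc1ccc(Nc2ncnc3ccc(Br)cc23)cc1` gives 13000 nM. For the measured compounds named here, the step of a 1.5-fold lower number from compound 2 to compound 3 (0.19 log units; within the scatter) lies within the scatter, so compound 3 cannot be told apart from its only numerical neighbour.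

Compound 4 `O=S(=O)(/C=C/c1ccc(O)cc1)Cc1ccc(Nc2ncnc3ccc(Br)cc23)cc1` is still unmeasured. It carries hydroxy in place of chloro on an aromatic carbon, para to a large group (hydroxy in place of chloro on an aromatic carbon). Going by the values given here, three measured steps bear on this ring. Among the compounds with values here, the one already given swaps one halogen for another at this same place and stays within the scatter. The other two, an at least 5.0-fold lower number from compound 1 to compound 2 (0.69 log units; beyond the scatter) and an at least 7.6-fold lower number from compound 1 to compound 3 (0.88 log units; beyond the scatter), lie beyond the scatter, so changes on this ring can matter. Within the data shown here, no measured compound carries hydroxy, which leaves the forecast uncertain in both directions. The expected move in this assay is therefore none beyond the scatter, and the estimated step is a 1.2-fold higher number from compound 3 to compound 4 (0.06 log units; within the scatter). For compound 4 the expected value is 15000 nM, with an estimated range from 4000 nM to 50000 nM.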

Compound 4, concentration for 50% growth inhibition: 27000 nM
Compound 4: the middle estimate sits 1.8-fold (0.26 log units) below what was measured; measured number inside the range.
By their numbers in this assay, from the lowest: compounds 3, 2 and 4 (each within the scatter of the next, the first and the last beyond it). At a limit, above all of these: compound 1.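

In this assay, the place on the aromatic ring para to a large group now carries a group other than a halogen. Hydroxy gives a 2.1-fold higher number from compound 3 to compound 4 (0.32 log units; beyond the scatter), a modest step just beyond the scatter, yet a 1.4-fold higher number from compound 2 to compound 4 (0.13 log units; within the scatter) stays within it, so hydroxy can be told apart from chloro but not from bromo, even though it brings a hydrogen-bond donor and acceptor that neither halogen has. The step of an at least 3.7-fold lower number from compound 1 to compound 4 (0.56 log units; beyond the scatter) also lies beyond the scatter, so compound 4 joins compound 2 and compound 3 in standing apart from compound 1, whose reading is a limit and not a number: the limit of > 100000 nM in this assay, at which 1 of the 4 values shown sits.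

The compounds shown leave open how an amine, a methoxy group or a carboxylic acid at this place would read. They also leave open whether any group here could give a number far lower than that of compound 3.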